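Dropping the Pyridine from Compound 1

This account rests on a few compounds, and the source may have more. Where it says the series, first, only, none or still open, it means among the compounds named here.

This study follows a small set of compounds in a functional assay on CHO cells for agonist activity at Alpha-1D adrenergic receptor (Homo sapiens), read by FLIPR and calcium flux; on this read-out higher numbers stand for an effect only at larger amounts of compound and lower numbers for an effect already at smaller amounts. Compound 1, `c1ccc(-c2cccc3c2CCC3c2ncc[nH]2)nc1`, is the starting point. In this assay compound 1 gives > 10000 nM, which is a limit of the assay. Compound 2, `Cn1ccc(-c2cccc3c2CCC3c2ncc[nH]2)n1`, differs from compound 1 in one group, and in this assay compound 2 gives > 10000 nM, again a limit. The step that the two limits leave unreadable from compound 1 to compound 2 therefore cannot be read in size or direction. Compound 3, `Cc1c(OCC2=NCCN2)ccc(Cl)c1NS(C)(=O)=O`, is built on another core, and in this assay compound 3 gives > 10000 nM, also a limit. Compound 1 thus stands at the same limit as every other value shown, which is summarised by the limit of > 10000 nM in this assay, at which 3 of the 3 values shown sit.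

Compound 4, `c1ccc2c(c1)CCC2c1ncc[nH]1`, has not yet been measured. It differs from compound 1 by hydrogen in place of pyridin-2-yl on an aromatic carbon. Within the data shown here, only one measured step touches the same place, the step from compound 1 to compound 2, and its size is hidden by the two limits. Among the measured compounds shown here, no measured step therefore shows how taking away the pyridin-2-yl should act in this assay, and no direction can be read. Compound 1 gives only a limit of > 10000 nM in this assay, and the expectation for compound 4 rests on that. Compound 4 is expected to show a step that the limit leaves unreadable from compound 1 to compound 4. The estimate for compound 4 is 20000 nM, within a range from 3000 nM to 100000 nM.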

Compound 4, half-maximal effective concentration: > 10000 nM
Compound 4: no number, only a limit (the forecaster's own chance of this, stated with the estimate: 75%); the middle value lies beyond the limit too.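

Compound 4, like compound 1 and compound 2, gives only a limit in this assay, so neither step to compound 4 can be read in size or direction. All the compounds shown share one result: the limit of > 10000 nM in this assay, at which 4 of the 4 values shown sit.

Still open is how pyridin-2-yl, 1-methyl-1H-pyrazol-3-yl and hydrogen compare on the shared core, and whether any compound shown has a measurable effect in this assay.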